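The compounds below may be only part of what the source reports. "The series", "measured", "known", "first", "only" and "open" are said of these compounds alone.

Measured so far in a functional assay on HSC-4 cells (Homo sapiens) for cytotoxicity, with a stated time of 24 h; on this read-out lower numbers stand for higher toxicity in this test and higher numbers for lower toxicity in this test:
Compound 1 `COc1cc(/C=C2\CCC/C(=C\c3ccccc3[N+](=O)[O-])C2=O)cc(OC)c1OC`: 6500 nM
Compound 2 `O=C1/C(=C/c2ccccc2)CCC/C1=C\c1ccc([N+](=O)[O-])cc1`: 9200 nM
Compound 3 `O=C1/C(=C/c2ccc(Cl)cc2)CCC/C1=C\c1ccc([N+](=O)[O-])cc1`: 2700 nM

Compound 1 is second highest of the three numbers, within the scatter of compound 2, while compound 3 lies beyond the scatter below it. Compound 4 `COc1cc(/C=C2\CCC/C(=C\c3ccc([N+](=O)[O-])cc3)C2=O)cc(OC)c1OC` has the same atoms as compound 1, joined differently: 4-nitrophenyl in place of 2-nitrophenyl on a double-bonded chain carbon bound to a double-bonded ring carbon. The change is 4-nitrophenyl in place of 2-nitrophenyl on a double-bonded chain carbon bound to a double-bonded ring carbon.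

Among the compounds with values here, no measured step covers this change. Within the data shown here, the only step available is a 3.4-fold lower number from compound 2 to compound 3 (0.53 log units; beyond the scatter), a modest one beyond the scatter, and it is a chloro-for-hydrogen change, so it bears only indirectly. It does show that compounds carrying the 4-nitrophenyl group can differ measurably, with compound 2 at 9200 nM and compound 3 at 2700 nM. Compound 1 at 6500 nM lies inside that span, so no step beyond the scatter is expected in this assay.

The expected change is a 1.3-fold lower number from compound 1 to compound 4 (0.11 log units; within the scatter).

Compound 4 is estimated at 5000 nM, with an expected range of 1700 nM to 14000 nM.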

Compound 4, half-maximal cytotoxic concentration: 1500 nM
Estimate against measurement, compound 4: 3.3-fold (0.52 log units) above; the whole stated range lies above it.
By their numbers in this assay, from the lowest: compounds 4 and 3 (each within the scatter of the next); then compounds 1 and 2 (each within the scatter of the next).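

In this assay, 4-nitrophenyl in place of 2-nitrophenyl on a double-bonded chain carbon bound to a double-bonded ring carbon gives a 4.3-fold lower number from compound 1 to compound 4 (0.64 log units; beyond the scatter). Within the data shown here, this is the first measured step at this place, and it shows that moving the nitro group on the phenyl ring is enough to shift the number beyond the scatter, although the two groups have the same atoms and the same counts of donors and acceptors. The comparison rests on a single pair sharing the core of compound 1, and no measured property bears on the reason for the step.

From the compounds shown here alone, whether 4-nitrophenyl gives a lower number than 2-nitrophenyl on other cores remains open. Also open, going by these compounds, is how 3-nitrophenyl, or an amine in place of the nitro group, would read at this place.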